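The source may hold more compounds than are shown below. What is called first, only, known or untested is meant among the compounds shown, and "the series" means these compounds.

Three compounds from one series have been run in a functional assay on the whole organism (Tail, strain ICR) with Mus musculus as the target, in the tail flick test, with a stated time of 150 min, at a dose of 25 umol/kg by the oral route; on this read-out lower numbers stand for a weaker effect and higher numbers for a stronger effect at the one dose given. Compound 1 `O=C(CN(c1nc(Cl)nc2[nH]cnc12)C1CC1)N[C@@H](CO)C(=O)OCc1ccccc1` gives 27.9% in this assay. Compound 2 `C[C@@H](O)[C@H](NC(=O)CN(c1nc(Cl)nc2[nH]cnc12)C1CC1)C(=O)OCc1ccccc1` gives 12.8% in this assay. These two differ by hydrogen in place of methyl on a saturated chain carbon bound to an oxygen on a saturated carbon and a saturated chain carbon and that change made a step of a number 15.1 percentage points higher from compound 2 to compound 1 (beyond the scatter). Compound 3 `C[C@@H](O)[C@H](NC(=O)CN(c1ncnc2c1ncn2C1CCCCO1)C1CC1)C(=O)OCc1ccccc1` carries a different core from compound 2; the difference between the two cores is not broken down here. In this assay compound 3 gives 6.53%, a number that lies within the scatter of compound 2 but beyond the scatter of compound 1.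

Compound 4 `O=C(CN(c1ncnc2c1ncn2C1CCCCO1)C1CC1)N[C@@H](CO)C(=O)OCc1ccccc1` has not yet been measured in this assay. It differs from compound 3 by hydrogen in place of methyl on a saturated chain carbon bound to an oxygen on a saturated carbon and a saturated chain carbon, the same change as from compound 2 to compound 1, at the same place. If that change carries over to the core of compound 3, a step of about a number 12.5 percentage points higher from compound 3 to compound 4 (beyond the scatter) would be expected, resting on the single earlier step of a number 15.1 percentage points higher from compound 2 to compound 1 (beyond the scatter), which is modest and comes from one pair only. On that basis compound 4 is estimated at 19%, with a range from 6% to 32%, given that compound 3 starts from 6.53%.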

Compound 4, a percentage reported as activity, at one dose (the size of the read-out at that dose, not a potency): 18.3%
For compound 4 the middle estimate is 0.7 percentage points above the measured one; measured number inside the range.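

In this assay, the change from 1-hydroxyethyl to hydroxymethyl gives a number 11.8 percentage points higher from compound 3 to compound 4 (beyond the scatter). Set beside the earlier step on the other core, the change carries over with no difference that can be told apart: the same change on two cores in this assay, a number 15.1 percentage points higher (beyond the scatter) from compound 2 to compound 1 and a number 11.8 percentage points higher (beyond the scatter) from compound 3 to compound 4, 3.3 percentage points apart, within the scatter of two such steps This rests on only two pairs and two cores, at one dose and one time, so it does not show that the change would carry over to any further core, and it says nothing about why the change acts as it does.

The compounds shown leave open how a longer chain or an amine at this place would read out on either core, since only 1-hydroxyethyl and hydroxymethyl can be compared here. On these data alone, it also remains open whether the two steps would stay this close at another dose or another time, as each compound has a single reading and these figures give the size of the effect, not a potency.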